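Shortening the hexylamino chain on a triazolopyrimidine core

The source may report more compounds than this note shows. Statements on the series, on what has been measured and on what is new or still open speak of the compounds shown alone.

Compound 1 `CCCCCCNc1nc(-c2ccccc2)nc2c1nnn2Cc1ccccc1` is one of two compounds tested in an assay on isolated protein for binding affinity to adenosine receptor A1 (Bos taurus) (a lower number here means a stronger inhibitor, a higher number a weaker inhibitor), where compound 1 gives 13200000 nM, the lowest of the two numbers. Within the data shown here, its neighbour compound 2 `CCCCCCNc1nc(-c2ccccc2)nc2c1nnn2Cc1ccccc1F` gives 25000000 nM, and the only measured step, a 1.9-fold higher number from compound 1 to compound 2 (0.28 log units; within the scatter), stays within the scatter. Compound 3 `CCCCNc1nc(-c2ccccc2)nc2c1nnn2Cc1ccccc1` differs from compound 1 by hydrogen in place of ethyl on a saturated chain carbon, four bonds along the chain from a nitrogen on an aromatic ring. Among the measured compounds shown here, no measured step touches this chain, so nothing in the data points to a direction; the one step known is small. Compound 3 is therefore expected to give 15000000 nM, between 5000000 nM and 45000000 nM, a change of a 1.1-fold higher number from compound 1 to compound 3 (0.06 log units; within the scatter).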

Compound 3, inhibition constant: 11000000 nM
Beside the measured number, compound 3's estimate is 1.4-fold (0.13 log units) above it, and the stated range covers the measured number.
By their numbers in this assay, from the lowest: compounds 3, 1 and 2 (each within the scatter of the next, the first and the last beyond it).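

In this assay, among these compounds, hydrogen in place of ethyl on this saturated chain carbon gives a 1.2-fold lower number from compound 1 to compound 3 (0.08 log units; within the scatter) and so provides the first measured step on the chain. At this position, this change is not separated from repeat measurement, and the same holds for the fluoro step. Nothing measured here offers an explanation for this result. As far as these compounds go, it remains open whether a longer chain, or a carboxylic acid in place of the ethyl, would give a step beyond the scatter. Also open, from the compounds shown here alone, is whether the fluoro change would read the same on the chain of compound 3.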